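From Thiophen-2-yl to Phenethyl on the Amide Carbonyl

A few compounds are considered here, and "the series" means these few. Any claim that something is new, unique, unknown or untested is made for them only; others in the source may bear on it.

Measured so far:
compound 1 `O=C(NCCCNc1nc(Nc2cccc(F)c2)ncc1Br)c1cccs1`: 9 nM
compound 2 `O=C(NCCCNc1nc(Nc2ccccc2F)ncc1C1CC1)c1cccs1`: 820 nM
compound 3 `O=C(NCCCNc1nc(Nc2cnn(C3CCOCC3)c2)ncc1C1CC1)C1CCC1`: 2 nM

In an assay on isolated protein for inhibition of serine/threonine-protein kinase TBK1 (Homo sapiens) (on this read-out higher numbers stand for weaker inhibition and lower numbers for stronger inhibition), compound 1 stands second highest of the three numbers. Its nearest neighbour is compound 3, with a lower number, and its furthest is compound 2, with a higher one; both gaps lie beyond the scatter. Among the measured compounds shown here, the three compounds differ in several places at once, so no single step among them can be read off.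

Compound 4 `O=C(CCc1ccccc1)NCCCNc1nc(Nc2cccc(F)c2)ncc1Br` differs from compound 1 in one place: phenethyl in place of thiophen-2-yl on a carbonyl carbon. For the measured compounds named here, no measured pair shows this change, so the expectation rests on the change alone. A moderate step towards a higher number is expected in a 3.3-fold higher number from compound 1 to compound 4 (0.52 log units; beyond the scatter), beyond the scatter but short of the gap to compound 2. Compound 4 is thus estimated at 30 nM, within 8 nM to 120 nM.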

Compound 4, half-maximal inhibitory concentration: 560 nM
Compound 4: the middle estimate sits 19-fold (1.27 log units) below what was measured, outside the stated range (above it).
By their numbers in this assay, from the lowest: compound 3; then compound 1; then compounds 4 and 2 (each within the scatter of the next).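

In this assay, the group on the carbonyl carbon proves decisive on the core of compound 1: phenethyl in place of thiophen-2-yl gives a 62-fold higher number from compound 1 to compound 4 (1.79 log units; beyond the scatter) in the only single-place step shown. The position therefore responds sharply to this change. Nothing shown accounts for the size of this step.

As far as these compounds go, it remains open whether the loss of thiophen-2-yl or the arrival of phenethyl drives the step, and whether benzyl, phenyl or furan-2-yl on the same carbonyl carbon would keep the number of compound 1. From the compounds shown here alone, whether the change would act alike on compound 2 or compound 3 also remains open.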